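Imine series: styryl for chlorophenyl on the imine carbon

The source may report more compounds than this note shows. Statements on the series, on what has been measured and on what is new or still open speak of the compounds shown alone.

The series is followed in an ADME assay on HeLa cells (Homo sapiens) for cytotoxicity, read by MTT assay, with a stated time of 72 h; on this read-out lower numbers stand for higher toxicity in this test and higher numbers for lower toxicity in this test. Compound 1 `Nc1sc2c(c1-c1nc3cc(Cl)ccc3s1)CCCC2` is the primary amine of the shared core; in this assay compound 1 gives 107 ug/mL. Within the data shown here, compound 2 `Clc1ccc(/C=N/c2sc3c(c2-c2nc4ccccc4s2)CCCC3)cc1` carries a 4-chlorophenyl on the imine carbon, and in this assay compound 2 gives 431 ug/mL, the higher of the two numbers so far, with the gap to compound 1 beyond the usual scatter. Among the measured compounds shown here, no further step between measured compounds is available.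

Compound 3 `C(=C/c1ccccc1)\C=N\c1sc2c(c1-c1nc3ccccc3s1)CCCC2` is the next member, still to be measured. Relative to compound 2 the change is 2-phenylethenyl in place of 4-chlorophenyl on a carbon with a double bond to nitrogen. Nothing measured in this set shows what such an exchange on the imine carbon does, so the expectation rests on compound 2 alone, and a step no larger than the scatter, in either direction, is expected from compound 2 to compound 3, namely a 1.2-fold lower number from compound 2 to compound 3 (0.09 log units; within the scatter). Compound 3 is therefore estimated at 350 ug/mL, within 150 ug/mL to 800 ug/mL.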

Compound 3, half-maximal cytotoxic concentration: 389 ug/mL
The estimate for compound 3 lay 1.1-fold (0.05 log units) below the measured number, within the range that was stated.
By their numbers in this assay, from the lowest: compound 1; then compounds 3 and 2 (each within the scatter of the next).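

Among these compounds, this is the first reading of a change on the imine carbon with the rest of the molecule held fixed: 2-phenylethenyl in place of 4-chlorophenyl gives a 1.1-fold lower number from compound 2 to compound 3 (0.04 log units; within the scatter) in this assay and so no separable difference between compound 2 and compound 3. The loss of the chlorine and the entry of a double bond outside aromatic rings, with a six-membered aromatic ring of carbon only present in both groups, therefore register as no readable shift on this read-out, for this one pair at this one position. Nothing available explains the result, and the step stands as a description only.

From the compounds shown here alone, whether the number also holds with a group of another kind on the imine carbon, such as a carboxylic acid or amine on the aromatic ring or a longer chain in place of 2-phenylethenyl, remains open. A plain phenyl on the imine carbon would be needed to separate the part played by the chlorine from that of the added double bond, since this pair changes both at once.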